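Moving the furan attachment point on a shared core

This account rests on a few compounds, and the source may have more. Where it says the series, first, only, none or still open, it means among the compounds named here.

Compound 3, `Oc1ccc(-c2cc(-c3ccco3)cc(-c3ccccc3O)n2)cc1`, is the reference point. In a functional assay on HeLa cells (Homo sapiens) for cytotoxicity, read by CCK-8 assay (on this read-out lower numbers stand for stronger inhibition and higher numbers for weaker inhibition), compound 3 gives > 50000 nM, which is a limit of the assay and not a number. The two neighbours measured so far fare no differently. Compound 1, `Oc1ccc(-c2cc(-c3ccsc3)cc(-c3ccccc3O)n2)cc1`, gives > 50000 nM in this assay, again a limit. Compound 2, `Oc1cccc(-c2cc(-c3ccco3)cc(-c3ccccc3O)n2)c1`, gives > 50000 nM in this assay, likewise a limit. The steps that lead to compound 3 therefore carry no readable size: a step that the two limits leave unreadable from compound 1 to compound 3 and a step that the two limits leave unreadable from compound 2 to compound 3. All three values sit at the same boundary, as the limit of > 50000 nM in this assay, at which 3 of the 3 values shown sit, records.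

Compound 4, `Oc1ccc(-c2cc(-c3ccoc3)cc(-c3ccccc3O)n2)cc1`, is the next variation, and it differs from compound 3 by furan-3-yl in place of furan-2-yl on an aromatic carbon. Going by the values given here, no measured step bears on this change with a readable size, and every compound on this core so far has stayed at the limit. Compound 4 is therefore expected to give 100000 nM in this assay, within 30000 nM to 500000 nM. The step from compound 3 to compound 4 that this estimate implies, a step that the limit leaves unreadable from compound 3 to compound 4, is expected to be none beyond the scatter, with the assay most likely again reporting only a limit.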

Compound 4, half-maximal inhibitory concentration: > 50000 nM
Compound 4 ended at the assay's limit; the forecaster's own chance of this, stated with the estimate: 85%; the middle value is on the limit's open side.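

In this assay, the steps to compound 4 from compound 3 and from compound 1 cannot be read, since all of these values are limits: the limit of > 50000 nM in this assay, at which 4 of the 4 values shown sit.

The compounds shown leave open whether any change on the shared core gives a readable value in this assay.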